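This account rests on a few compounds, and the source may have more. Where it says the series, first, only, none or still open, it means among the compounds named here.

Compound 1 `NC(=O)c1c(NC(=O)c2ccccc2C(F)(F)F)sc2c1CCN(C(=S)Nc1ccccc1Cl)C2` gives 17600 nM in a functional assay on HL-60 cells (Homo sapiens) for antiproliferative activity, with a stated time of 24 h; on this read-out higher numbers stand for weaker inhibition and lower numbers for stronger inhibition.
Compound 2 `NC(=O)c1c(NC(=O)c2ccccc2Br)sc2c1CCN(C(=S)Nc1ccccc1F)C2` gives > 50000 nM in this assay.

The value for compound 2 is a limit of the assay, not a number, and it sits at the limit of > 50000 nM in this assay, at which 1 of the 2 values shown sits. Compound 3 `NC(=O)c1c(NC(=O)c2ccccc2C(F)(F)F)sc2c1CCN(C(=S)Nc1ccccc1F)C2` has not been measured yet; it differs from compound 2 by trifluoromethyl in place of bromo on an aromatic carbon. Compound 1 carries the same trifluoromethyl group and gives a measurable 17600 nM, so the exchange is expected to move the value into the measurable range, a step of an at least 1.6-fold lower number from compound 2 to compound 3 (0.22 log units; that floor lies within the scatter) toward stronger inhibition. Compound 3 is therefore estimated at 30000 nM, with a range from 10000 nM to 60000 nM.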

Compound 3, half-maximal inhibitory concentration: 23500 nM
Beside the measured number, compound 3's estimate is 1.3-fold (0.11 log units) above it; the measured number falls inside the stated range.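

In this assay, trifluoromethyl in place of bromo on this aromatic carbon gives an at least 2.1-fold lower number from compound 2 to compound 3 (0.32 log units; beyond the scatter). The value of compound 2 is a limit of the assay, not a number, so only a minimum for this step can be read: the limit of > 50000 nM in this assay, at which 1 of the 3 values shown sits. With trifluoromethyl in place, fluoro in place of chloro on an aromatic carbon gives a 1.3-fold higher number from compound 1 to compound 3 (0.13 log units; within the scatter).

From the compounds shown here alone, the full size of the step from bromo to trifluoromethyl remains open. So does how a methyl group or an amine on the same aromatic carbon would compare.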